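The compounds below may be only part of what the source reports. "The series", "measured", "known", "first", "only" and "open" are said of these compounds alone.

Measured so far:
- compound 1 `Cc1c(Nc2nc(N)c3c(C#N)c(N4CCC[C@H]4C)n(C)c3n2)cnn1[C@H]1CCOC1` gives 23.3 mL/min/kg
- compound 2 `Cc1nn(CC(C)(C)O)cc1Nc1nc(N)c2c(C#N)c(N3CCC[C@H]3C)n(C)c2n1` gives 50 mL/min/kg
- compound 3 `C[C@@H]1CCCN1c1c(C#N)c2c(N)nc(Nc3cn(C)nc3Cl)nc2n1C` gives 183 mL/min/kg

In an ADME assay on microsomes from liver (Homo sapiens) for pharmacokinetics (a higher number here means faster removal of the compound, a lower number slower removal), compound 3 stands highest of the three, with both compound 2 and compound 1 lower by more than the scatter. Compound 4 `C[C@@H]1CCCN1c1c(C#N)c2c(N)nc(Nc3cn(C)nc3C(F)(F)F)nc2n1C` is not yet measured. It carries trifluoromethyl in place of chloro on an aromatic carbon. Among the measured compounds shown here, no measured pair differs in one place only, so the data hold no direct precedent for this change. A small fall, within the scatter, is expected a 1.4-fold lower number from compound 3 to compound 4 (0.15 log units; within the scatter). For compound 4 the estimated clearance is 130 mL/min/kg, with an expected range of 60 mL/min/kg to 260 mL/min/kg.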

Compound 4, clearance: 33.3 mL/min/kg
Beside the measured number, compound 4's estimate is 3.9-fold (0.59 log units) above it, and the stated range ends above it.
By their numbers in this assay, from the lowest: compounds 1, 4 and 2 (each within the scatter of the next, the first and the last beyond it); then compound 3.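

In this assay, among the compounds shown here, trifluoromethyl in place of chloro on this aromatic carbon gives a 5.5-fold lower number from compound 3 to compound 4 (0.74 log units; beyond the scatter), the first comparison that differs in one place only. The position next to the ring nitrogen is therefore not silent for this read-out: this single change moves the number beyond the scatter. No measurement at hand accounts for the shift. As far as these compounds go, whether fluoro, methoxy or a nitrile at this position would give a similar step remains open. So does whether the step carries over when the methyl on the ring nitrogen is replaced by a longer chain.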